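The compounds below may be only part of what the source reports. "The series", "measured", "known", "first", "only" and "open" are said of these compounds alone.

Measured so far:
- compound 1, `CCn1c(SCC(=O)c2ccccc2)nnc1-c1ccc(OC)cc1`: 67%
- compound 2, `C=CCn1c(SCC(=O)c2ccccc2)nnc1-c1ccc(OC)c(OC)c1`: 64%

In a functional assay on the whole organism (strain albino) for inhibition, with Rattus norvegicus as the target, read by paw edema, with a stated time of 3 h, at a dose of 0.28 mmol/kg by the oral route (on this read-out higher numbers stand for more inhibition at the one dose given (going by the name of the read-out) and lower numbers for less inhibition), compound 1 gives 67% and compound 2 gives 64%; the two numbers stand within the scatter of each other, so no order between them can be read. Compound 3, `C=CCn1c(SCC(=O)c2ccccc2)nnc1-c1ccc(OC)cc1`, is unmeasured. It differs from compound 2 as follows: hydrogen in place of methoxy on an aromatic carbon. Among the compounds with values here, no step between measured compounds bears on this change. The two measured values leave no ground for a step beyond the scatter, so none is expected, and the estimated step of a number 1 percentage points higher from compound 2 to compound 3 (within the scatter) reflects that. Compound 3 is accordingly expected to give about 65% in this assay, in the range 50% to 78%.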

Compound 3, a percentage reported as inhibition, in the whole organism at one dose (the size of the read-out at that dose, not a potency): 63%
The estimate for compound 3 lay 2 percentage points above the measured number; the range from low to high includes it.
By their numbers in this assay, from the lowest: compounds 3, 2 and 1 (each within the scatter of the next).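

In this assay hydrogen in place of methoxy on the aromatic carbon gives a number 1 percentage points lower from compound 2 to compound 3 (within the scatter) and thus no readable change at this position. Vinyl in place of methyl on the saturated chain carbon bound to the aromatic nitrogen gives a number 4 percentage points lower from compound 1 to compound 3 (within the scatter) and likewise no readable change at that place. Nothing measured here offers a reason for either result.

Open, going by these compounds, is whether an amine on that aromatic carbon, or a longer chain on that aromatic nitrogen, would move the number beyond the scatter. On these data alone, with a single dose, any order of potency also stays open.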